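Swapping Bromo for Fluoro on a Pendant Aromatic Ring

The compounds below may be only part of what the source reports. "The series", "measured", "known", "first", "only" and "open" are said of these compounds alone.

Compound 1 `CCCn1c(=O)[nH]c2nc(-c3ccc(S(=O)(=O)N4CCN(c5ccccc5C)CC4)cc3)[nH]c2c1=O`: 419 nM
Compound 2 `CCCn1c(=O)[nH]c2nc(-c3ccc(S(=O)(=O)N4CCN(C)CC4)cc3)[nH]c2c1=O`: 334 nM
Compound 3 `CCCn1c(=O)[nH]c2nc(-c3ccc(S(=O)(=O)N4CCN(c5cccc(Br)c5)CC4)cc3)[nH]c2c1=O`: > 1000 nM

Three compounds sharing one core were measured in an assay on CHO cells for displacement of a labelled ligand from adenosine receptor A1 (Homo sapiens), read by scintillation counting, with a stated time of 90 min, in the presence of a further agent that is not named here; a higher number here means a weaker inhibitor, a lower number a stronger inhibitor. Compound 1 gives 419 nM. Compound 2 gives 334 nM, and the change a 1.3-fold lower number from compound 1 to compound 2 (0.10 log units; within the scatter) stays within the scatter. Compound 3 gives only a limit of the assay, > 1000 nM, so no number is known for it, and it sits at the weak end of the set (the limit of > 1000 nM in this assay, at which 1 of the 3 values shown sits). The steps of an at least 2.3-fold higher number from compound 1 to compound 3 (0.37 log units; beyond the scatter) and an at least 2.9-fold higher number from compound 2 to compound 3 (0.47 log units; beyond the scatter) are both beyond the scatter.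

Compound 4 `CCCn1c(=O)[nH]c2nc(-c3ccc(S(=O)(=O)N4CCN(c5cccc(F)c5)CC4)cc3)[nH]c2c1=O` differs from compound 3 by the change (fluoro in place of bromo on an aromatic carbon). Among the measured compounds shown here, no measured step exchanges one halogen for another, so the two steps into compound 3 bear on it only by fixing where compound 3 stands. Compound 4 is therefore expected to remain near that limit, with a step that the limit leaves unreadable from compound 3 to compound 4 not clearly beyond the scatter. The estimate for compound 4 in this assay is 1100 nM, ranging from 400 nM to 3000 nM.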

Compound 4, inhibition constant: > 1000 nM
Compound 4: a limit, no number; the forecaster's own chance of this, stated with the estimate: 45%; the middle value is on the limit's open side.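

In this assay compound 4 also ends at a limit of the assay, so the weak end of the set now holds two compounds that differ only in the halogen on the aromatic carbon: the limit of > 1000 nM in this assay, at which 2 of the 4 values shown sit.

With limits on both sides, the step for fluoro in place of bromo cannot be read. On the amine nitrogen in a ring, the 3-fluorophenyl group still stands apart from the other two groups, with an at least 2.9-fold higher number from compound 2 to compound 4 (0.47 log units; beyond the scatter) and an at least 2.3-fold higher number from compound 1 to compound 4 (0.37 log units; beyond the scatter), so the weak reading does not belong to the bromo compound alone.

From the compounds shown here alone, how far past the limit compound 3 and compound 4 lie stays open, and with it any difference between the two halogens. Also open, going by these compounds, is whether a chloro, methoxy or nitrile group on the same aromatic carbon would give a value inside the limit.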